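Adding a Methoxy to a Weakly Inhibiting Compound

The source may hold more compounds than are shown below. What is called first, only, known or untested is meant among the compounds shown, and "the series" means these compounds.

In a functional assay on NCI-H460 cells (Homo sapiens) for inhibition, read by sulforhodamine B assay, with a stated time of 48 h (on this read-out higher numbers stand for weaker inhibition of growth and lower numbers for stronger inhibition of growth), compound 1 `C=C(C)[C@@H]1CC=C(Cn2cc(COc3ccc(C4NC(=O)NC(C)=C4C(C)=O)cc3)nn2)CC1` gives 78200 nM. Compound 2 `C=C(C)[C@@H]1CC=C(Cn2cc(COc3cccc(C4NC(=O)NC(C)=C4C(C)=O)c3)nn2)CC1` reaches only the limit > 100000 nM in this assay. Compound 3 `C=C(C)[C@@H]1CC=C(Cn2cc(COc3cc(C4NC(=O)NC(C)=C4C(C)=O)ccc3OC)nn2)CC1` likewise reaches only the limit > 100000 nM in this assay. Compound 3 differs from compound 2 by a methoxy in place of hydrogen on an aromatic carbon, and a step that the two limits leave unreadable from compound 2 to compound 3, since both values sit at the limit of > 100000 nM in this assay, at which 2 of the 3 values shown sit. The difference between the cores of compound 1 and compound 2 is not broken down here. Compound 4 `C=C(C)[C@@H]1CC=C(Cn2cc(COc3ccc(C4NC(=O)NC(C)=C4C(C)=O)cc3OC)nn2)CC1` is not yet measured; it carries the same kind of change relative to compound 1 (methoxy in place of hydrogen on an aromatic carbon), here ortho to a large group and meta to a large group, whereas in compound 3 the methoxy is ortho to a large group and para to a large group. Compound 1 already inhibits growth only weakly with 78200 nM, and the measured step gives no readable size. For compound 4 the expected step is therefore a 1.2-fold higher number from compound 1 to compound 4 (0.08 log units; within the scatter), small in this assay. Compound 4 is estimated at 95000 nM, between 40000 nM and 220000 nM, with a real chance that only a limit is reported.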

Compound 4, concentration for total growth inhibition: > 100000 nM
Compound 4: a limit, no number; the forecaster's own chance of this, stated with the estimate: 55%; at least 1.0-fold (0.02 log units) between middle value and limit.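

Placing the methoxy in place of hydrogen on an aromatic carbon on the core of compound 1 gives an at least 1.2-fold higher number from compound 1 to compound 4 (0.10 log units; that floor lies within the scatter) in this assay, so the true size of this step stays open. Compound 4 reaches only a limit, > 100000 nM, and not a number. The same change on the core of compound 2 cannot be read, so the two steps cannot be compared and the data do not show whether the change carries over in size, because the values on that core sit at the limit: the limit of > 100000 nM in this assay, at which 3 of the 4 values shown sit.

The compounds shown leave open how an amine, a carboxylic acid or a longer ethoxy chain at this place would read in this assay. They also leave open whether any group here would bring a value clear of the limit.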